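Replacing a para chloro with thiophen-2-yl on the phenoxyacetamide

The source may report more compounds than this note shows. Statements on the series, on what has been measured and on what is new or still open speak of the compounds shown alone.

The measured compounds:
- compound 1, `Cc1ccc(OCC(=O)Nc2cccc(C(=O)O)c2)cc1`: > 30000 nM
- compound 2, `CC(C)(C)c1ccc(OCC(=O)Nc2cccc(C(=O)O)c2)cc1`: 9500 nM
- compound 3, `O=C(COc1ccc(Cl)cc1)Nc1cccc(C(=O)O)c1`: 10000 nM

In a functional assay on AGS cells (Homo sapiens) for inhibition, read by reporter gene assay (a lower number here means a stronger inhibitor, a higher number a weaker inhibitor), compound 1 gives only a limit, > 30000 nM, so its number is not known. Compound 2 gives 9500 nM in this assay. Compound 3 gives 10000 nM in this assay, the highest of the two numbers, though the gap to compound 2, a 1.1-fold higher number from compound 2 to compound 3 (0.02 log units; within the scatter), is within the scatter. Both substituted analogues fall beyond the limit of compound 1: an at least 3.1-fold lower number from compound 1 to compound 2 (0.49 log units; beyond the scatter) and an at least 3.0-fold lower number from compound 1 to compound 3 (0.47 log units; beyond the scatter).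

Compound 4, `O=C(COc1ccc(-c2cccs2)cc1)Nc1cccc(C(=O)O)c1`, has not yet been measured in this assay. It differs from compound 3 as follows: thiophen-2-yl in place of chloro on an aromatic carbon. The measured steps show that enlarging the group at this position, methyl to tert-butyl, gave a lower number, and that tert-butyl and chloro are interchangeable within the scatter. Thiophen-2-yl is larger again, so a lower number for compound 4 is expected, of modest size: a 2.5-fold lower number from compound 3 to compound 4 (0.40 log units; beyond the scatter). Compound 4 is expected to give about 4000 nM in this assay, within the range 1000 nM to 15000 nM.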

Compound 4, half-maximal inhibitory concentration: > 30000 nM
Compound 4 was reported as a limit; the forecaster's own chance of this, stated with the estimate: 10%; middle value at least 7.5-fold (0.87 log units) away from the limit.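

Thiophen-2-yl at this position breaks the trend suggested by the earlier compounds, in which the larger tert-butyl and the chloro both beat methyl in this assay: it moves the number the other way, with an at least 3.0-fold higher number from compound 3 to compound 4 (0.47 log units; beyond the scatter) and an at least 3.1-fold higher number from compound 2 to compound 4 (0.49 log units; beyond the scatter). Size alone therefore does not order the groups here, and compound 4 goes against any rule that a larger group gives a lower number. Compound 1 and compound 4 are both reported as limits, so the step between them cannot be read: the limit of > 30000 nM in this assay, at which 2 of the 4 values shown sit.

From the compounds shown here alone, it remains open whether this loss belongs to the thiophene ring itself or to any aromatic ring on this carbon, which a phenyl or furan-2-yl group would test. Going by these compounds, how a bromo or methoxy group compares with chloro at this position also remains open.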